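Adding a Methyl to the Nitrogen of Compound 1

A few compounds are considered here, and "the series" means these few. Any claim that something is new, unique, unknown or untested is made for them only; others in the source may bear on it.

For the measured compounds named here, in a functional assay on NCI-H460 cells (Homo sapiens) for inhibition, with a stated time of 72 h (a higher number here means a weaker inhibitor, a lower number a stronger inhibitor), compound 1 (`COc1cc(C(=O)c2ccc3[nH]ccc3c2)cc(OC)c1OC`) gives 112 nM, the middle of the three numbers so far. Compound 2 (`COc1cc(C(=O)c2ccc3cc[nH]c3c2)cc(OC)c1OC`) is a weaker inhibitor at 520 nM, while compound 3 (`COc1cc(C(=O)c2cccc3c2ccn3C)cc(OC)c1OC`) is a stronger one at 28.8 nM. The next compound to test is compound 4 (`COc1cc(C(=O)c2ccc3c(ccn3C)c2)cc(OC)c1OC`), which differs from compound 1 by methyl in place of hydrogen on an aromatic nitrogen. Going by the values given here, no measured pair shows this change alone. Compound 3 also has a methyl on an aromatic nitrogen and gives 28.8 nM, but its structure differs in another way too, so it is only a weak guide. A small step toward a lower number is expected, a 1.9-fold lower number from compound 1 to compound 4 (0.27 log units; within the scatter). For compound 4, the estimate is 60 nM, with an expected range from 15 nM to 240 nM.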

Compound 4, half-maximal inhibitory concentration: 14.1 nM
Beside the measured number, compound 4's estimate is 4.3-fold (0.63 log units) above it; measured number below the stated range.
By their numbers in this assay, from the lowest: compound 4; then compound 3; then compound 1; then compound 2.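

In this assay, for the compounds shown here, methyl in place of hydrogen on an aromatic nitrogen gives a 7.9-fold lower number from compound 1 to compound 4 (0.90 log units; beyond the scatter) with nothing else in the structure altered, the first direct reading of this change. For this pair, the hydrogen on this nitrogen is therefore not needed for inhibition, and the position takes a methyl with a gain beyond the scatter. Nothing measured here explains why the number falls. On these data alone, whether an ethyl, a longer chain or a chain ending in an amine on this nitrogen would keep the gain stays open. So does whether a methyl would bring a similar step to compound 2, which still carries the hydrogen on its nitrogen.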